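Capping the benzylic hydroxyl of a chemokine receptor antagonist

This account rests on a few compounds, and the source may have more. Where it says the series, first, only, none or still open, it means among the compounds named here.

In a functional assay on CEM-CCRF cells for antagonist activity at C-X-C chemokine receptor type 4 (Homo sapiens), read by calcium flux (on this read-out higher numbers stand for weaker inhibition and lower numbers for stronger inhibition), compound 1 `NCc1cc(C(F)(F)F)ccc1CN(Cc1nc2ccccc2[nH]1)C1CCCc2cccnc21` gives 51 nM, and compound 2 `NCc1cc(CO)ccc1CN(Cc1nc2ccccc2[nH]1)C1CCCc2cccnc21` gives 11 nM, the lowest of the two numbers. For the measured compounds named here, the only known step, a 4.6-fold lower number from compound 1 to compound 2 (0.67 log units; beyond the scatter), concerns the same position on the aryl ring. Compound 3 `COCc1ccc(CN(Cc2nc3ccccc3[nH]2)C2CCCc3cccnc32)c(CN)c1` differs from compound 2 by methyl in place of hydrogen on an oxygen on a saturated carbon. Going by the values given here, no measured step covers this methylation, so only a cautious inference is possible: compound 3 is expected to give 20 nM in this assay, within 6 nM to 65 nM, the estimated step of a 1.8-fold higher number from compound 2 to compound 3 (0.26 log units; within the scatter) lying near the scatter.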

Compound 3, half-maximal inhibitory concentration: 21 nM
Compound 3: the middle estimate sits 1.1-fold (0.02 log units) below what was measured, and the stated range covers the measured number.
By their numbers in this assay, from the lowest: compounds 2 and 3 (each within the scatter of the next); then compound 1.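

Methyl in place of hydrogen on this oxygen gives a 1.9-fold higher number from compound 2 to compound 3 (0.28 log units; within the scatter) in this assay, so a free hydroxyl is not required for a number in this range among these compounds. In place of trifluoromethyl, methoxymethyl gives a 2.4-fold lower number from compound 1 to compound 3 (0.39 log units; beyond the scatter) on the same aromatic carbon, so both oxygen-bearing groups shown give lower numbers than compound 1 does. On these data alone, whether a longer chain on this oxygen, an amine or a carboxylic acid would keep the number in this range remains open. Nothing shown gives a reason for either step.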